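Furan in place of fluorophenyl on a pyrazolopyrimidinone scaffold

This account rests on a few compounds, and the source may have more. Where it says the series, first, only, none or still open, it means among the compounds named here.

Among the compounds with values here, compound 2 `O=C(Nn1c(-c2cccc([N+](=O)[O-])c2)nc2c(-c3ccc(F)cc3)n[nH]c2c1=O)c1ccccc1` stands highest of the two numbers measured so far: in a functional assay on DU-145 cells (Homo sapiens) for cytotoxicity, read by sulforhodamine B assay, with a stated time of 2 days, tested at 100 uM (on this read-out higher numbers stand for more inhibition at the one concentration tested (going by the name of the read-out) and lower numbers for less inhibition), compound 2 gives 90.8%, while compound 1 `CCCc1n[nH]c2c(=O)n(NC(=O)c3ccccc3)c(-c3cccc([N+](=O)[O-])c3)nc12` gives 27.8%. Within the data shown here, the one measured step, a number 63 percentage points higher from compound 1 to compound 2 (beyond the scatter), shows that an aromatic ring at this position matters greatly. Compound 3 `O=C(Nn1c(-c2cccc([N+](=O)[O-])c2)nc2c(-c3ccco3)n[nH]c2c1=O)c1ccccc1` differs from compound 2 by furan-2-yl in place of 4-fluorophenyl on an aromatic carbon. Since both groups are aromatic rings, he expects the step of a number 15.8 percentage points lower from compound 2 to compound 3 (beyond the scatter) to be modest, likely a small decrease. Compound 3 is estimated at 75%, ranging from 45% to 95%.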

Compound 3, a percentage reported as inhibition, at one concentration (the size of the read-out at that concentration, not a potency): 16.1%
The estimate for compound 3 lay 58.9 percentage points above the measured number; measured number outside the range, below it.
By their numbers in this assay, from the lowest: compound 3; then compound 1; then compound 2.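

An aromatic ring on this carbon is not enough by itself, as furan-2-yl for 4-fluorophenyl gives a number 74.7 percentage points lower from compound 2 to compound 3 (beyond the scatter) and the high number is lost. Furan-2-yl also falls short of propyl, with a number 11.7 percentage points lower from compound 1 to compound 3 (beyond the scatter) here, so the earlier gain belongs to 4-fluorophenyl and not to aromatic rings in general. Nothing available explains the gap between these two rings.

On these data alone, whether the gain depends on ring size, the fluorine or the furan oxygen stays open. Unsubstituted phenyl and a pyridine ring on this carbon would help separate these.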